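The source may hold more compounds than are shown below. What is called first, only, known or untested is meant among the compounds shown, and "the series" means these compounds.

Compound 1 `COC[C@]1(C(=O)N2CC[C@](c3ccc(C(F)(C(F)(F)F)C(F)(F)F)cc3)(S(=O)(=O)c3ccc(F)cc3)C2)CC[C@H](C(=O)O)CC1`: 100%
Compound 2 `O=C(N1CC[C@](c2ccc(C(F)(C(F)(F)F)C(F)(F)F)cc2)(S(=O)(=O)c2ccc(F)cc2)C1)C12CCC(C(=O)O)(CC1)OC2`: "not determined" (no result reported)
Compound 3 `O=C([C@H]1CC[C@H](c2nnn[nH]2)CC1)N1CC[C@](c2ccc(C(F)(C(F)(F)F)C(F)(F)F)cc2)(S(=O)(=O)c2ccc(F)cc2)C1`: 100%

All readings are from an ADME assay on microsomes from liver (Homo sapiens) for metabolic stability, with a stated time of 10 min; a lower number here means that less of the compound is left, a higher number that more of the compound is left. Compound 3 stands at 100%, level with compound 1, and compound 2 gives no usable comparison. The next change leads to compound 4 `O=C(C1CCS(=O)(=O)CC1)N1CC[C@](c2ccc(C(F)(C(F)(F)F)C(F)(F)F)cc2)(S(=O)(=O)c2ccc(F)cc2)C1`: 1,1-dioxothian-4-yl in place of 4-(1H-tetrazol-5-yl)cyclohexyl on a carbonyl carbon. In words, 1,1-dioxothian-4-yl replaces 4-(1H-tetrazol-5-yl)cyclohexyl on a carbonyl carbon, and the shared core stays as it is.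

For the measured compounds named here, only one measured step bears on this, no change at the digits printed from compound 1 to compound 3 (within the scatter). It shows that one exchange at this same carbonyl carbon left this assay unmoved. Going by the values given here, that exchange involved other groups, though, and no measured compound carries 1,1-dioxothian-4-yl, so the evidence is indirect. With compound 3 at 100%, any clear move could only be downward. A small drop, no larger than the usual scatter, is therefore expected: a number 8 percentage points lower from compound 3 to compound 4 (within the scatter). For compound 4 the estimated value is 92%, with an expected range of 72% to 100%.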

Compound 4, percent of the compound remaining: 93%
Compound 4: middle estimate off by 1 percentage points, on the low side; measured number inside the range.
By their numbers in this assay, from the lowest: compounds 4, 1 and 3 (each within the scatter of the next).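

In this assay, the exchange at this carbonyl carbon now extends beyond the substituted cyclohexyl groups: 1,1-dioxothian-4-yl, with a ring sulfur and 0 hydrogen-bond donors, gives a number 7 percentage points lower from compound 3 to compound 4 (within the scatter) and a number 7 percentage points lower from compound 1 to compound 4 (within the scatter). The reading therefore holds within the scatter across three different groups on this carbonyl carbon, including one with neither a carboxylic acid nor a tetrazole, and with 8 heavy atoms, fewer than in 4-(1H-tetrazol-5-yl)cyclohexyl. No available evidence accounts for this outcome.

On these data alone, whether the same holds for an amine on this carbonyl carbon, or for an open-chain sulfone in place of the ring, remains open. The shown compounds also leave open whether exchanges elsewhere on the shared core, such as replacing the fluorine on the aryl sulfone with a methoxy group, would move this assay.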